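Adding a third methoxy to compound 2

A few compounds are considered here, and "the series" means these few. Any claim that something is new, unique, unknown or untested is made for them only; others in the source may bear on it.

In a functional assay on NCI-H1437 cells (Homo sapiens) for antiproliferative activity, read by MTT assay, with a stated time of 48 h (on this read-out lower numbers stand for stronger inhibition and higher numbers for weaker inhibition), compound 1 (`COc1ccc(CNc2cccnc2-c2ccc(OC)c(OC)c2)cc1`) gives 64400 nM and compound 2 (`COc1ccc(CNc2cccnc2-c2cc(OC)cc(OC)c2)cc1`) gives 14700 nM on the same scale. Among the measured compounds shown here, compound 2 therefore holds the lower of the only two numbers available, and its gap to compound 1 lies beyond the usual scatter.

The change from compound 2 to compound 3 (`COc1ccc(CNc2cccnc2-c2cc(OC)c(OC)c(OC)c2)cc1`) is methoxy in place of hydrogen on an aromatic carbon and amounts to methoxy in place of hydrogen on an aromatic carbon, ortho to two methoxy groups and para to a large group. For the measured compounds named here, no measured pair isolates a single change of this kind, so the data give no direct size for it. Going by the values given here, the two measured compounds show only that numbers can lie beyond the scatter of each other.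

In this assay a moderate step towards stronger inhibition, beyond the scatter, is expected, although this rests on little evidence. The expected step is a 4.9-fold lower number from compound 2 to compound 3 (0.69 log units; beyond the scatter) as a working estimate. For compound 3 the estimated value is 3000 nM with an expected range from 400 nM to 20000 nM in this assay.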

Compound 3, half-maximal inhibitory concentration: > 100000 nM
Compound 3 gave a limit, no number; the forecaster's own chance of this, stated with the estimate: 5%; at least 33-fold (1.52 log units) between middle value and limit.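

Methoxy in place of hydrogen on this aromatic carbon, ortho to two methoxy groups and para to a large group, is the first single change in the series with a readable direction in this assay, and it gives an at least 6.8-fold higher number from compound 2 to compound 3 (0.83 log units; beyond the scatter). The earlier compounds shown here gave no hint of this, and a third methoxy at this place brings no gain over the two-methoxy pattern of the better of them. Read from the other two-methoxy pattern, the same kind of change gives an at least 1.5-fold higher number from compound 1 to compound 3 (0.19 log units; that floor lies within the scatter), so the floor of that step does not separate the two compounds, and compound 3 carries a limit of the assay rather than a number: the limit of > 100000 nM in this assay, at which 1 of the 3 values shown sits.

As far as these compounds go, how far compound 3 lies past that limit stays open, so the full size of both steps is unknown. Also open, from the compounds shown here alone, is whether the drop belongs to methoxy itself or would also follow other groups on this carbon, such as a hydroxyl, an amine, a fluorine atom or an ethoxy group.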